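Furan-3-yl for ethynyl on a second core

This account rests on a few compounds, and the source may have more. Where it says the series, first, only, none or still open, it means among the compounds named here.

Compound 1 `C#Cc1cn([C@@H]2O[C@H](CO)[C@@H](O)[C@H]2O)c2ncnc(C)c12` carries an ethynyl group on its core. In a functional assay on HL-60 cells (Homo sapiens) for antiproliferative activity, read by XTT assay, with a stated time of 72 h (a lower number here means a stronger inhibitor, a higher number a weaker inhibitor), compound 1 gives 1110 nM. Compound 2 `Cc1ncnc2c1c(-c1ccoc1)cn2[C@@H]1O[C@H](CO)[C@@H](O)[C@H]1O` differs from compound 1 by furan-3-yl in place of ethynyl on an aromatic carbon. In this assay compound 2 is reported only as a limit, > 15000 nM, not as a number, which is the limit of > 15000 nM in this assay, at which 1 of the 3 values shown sits. The step from the measured pair is an at least 13-fold higher number from compound 1 to compound 2 (1.13 log units; beyond the scatter).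

Compound 3 `C#Cc1cn([C@@H]2O[C@H](CO)[C@@H](O)[C@H]2O)c2nc(N)nc(OC)c12` stands on a different core; the difference between the core of compound 1 and the core of compound 3 is not broken down here. In this assay compound 3 is reported only as a limit, > 20000 nM, which is the limit of > 20000 nM in this assay, at which 1 of the 3 values shown sits.

Compound 4 `COc1nc(N)nc2c1c(-c1ccoc1)cn2[C@@H]1O[C@H](CO)[C@@H](O)[C@H]1O` is not yet measured. It differs from compound 3 by furan-3-yl in place of ethynyl on an aromatic carbon. The place is described in the same words as for the change between compound 1 and compound 2, so this is the same kind of change made on a second core.

Going by the values given here, compound 3 already sits at a limit, and the only measured instance of the change gave an at least 13-fold higher number from compound 1 to compound 2 (1.13 log units; beyond the scatter), a weakening. Compound 4 is therefore expected to remain at or beyond a limit, with an expected step that the limit leaves unreadable from compound 3 to compound 4. For compound 4 the estimate in this assay is 50000 nM, with an expected range from 20000 nM to 300000 nM, and most likely only a limit will be reported.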

Compound 4, half-maximal inhibitory concentration: > 20000 nM
Compound 4: no number, only a limit (the forecaster's own chance of this, stated with the estimate: 95%); the middle value lies beyond the limit too.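

In this assay compound 4 gives > 20000 nM, a limit and not a number. Going by these compounds alone, compound 3 likewise stands at a limit, > 20000 nM, so no step between compound 3 and compound 4 can be read. The compounds shown leave open whether furan-3-yl in place of ethynyl has the same effect on the core of compound 3 as on the core of compound 1.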